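Swapping a Pyridine for a Benzofuran on a Shared Core

A few compounds are considered here, and "the series" means these few. Any claim that something is new, unique, unknown or untested is made for them only; others in the source may bear on it.

Measured compounds:
- Compound 1 `O=C(c1ccc(F)cc1)c1cccc(/C=c2\[nH]c(=O)/c(=C/c3nc[nH]c3C3CC3)[nH]c2=O)c1` gives 2.8 nM in a functional assay on NCI-H460 cells (Homo sapiens) for cytotoxicity, read by MTT assay, with a stated time of 72 h; a lower number here means a stronger inhibitor, a higher number a weaker inhibitor.
- Compound 3 `Cc1ccc(/C=c2\[nH]c(=O)/c(=C/c3cccc(C(=O)c4ccc(F)cc4)c3)[nH]c2=O)o1` gives 5.3 nM in this assay.
- Compound 2 `O=c1[nH]/c(=C\c2cccc(Oc3ccc(F)cc3)c2)c(=O)[nH]/c1=C\c1cccnc1` gives only a limit, > 1000 nM, in this assay.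

Compound 2 thus stands at the limit of > 1000 nM in this assay, at which 1 of the 3 values shown sits, so no number is known for it, only that limit. Compound 4 `O=c1[nH]/c(=C\c2cc3ccccc3o2)c(=O)[nH]/c1=C\c1cccc(Oc2ccc(F)cc2)c1` differs from compound 2 by 1-benzofuran-2-yl in place of pyridin-3-yl on a double-bonded chain carbon bound to an aromatic carbon. For the measured compounds named here, the only measured step at the same place, a 1.9-fold higher number from compound 1 to compound 3 (0.28 log units; within the scatter), exchanges one aromatic group for another without moving beyond the scatter. On that single precedent, no step beyond the scatter is expected here either, so a step that the limit leaves unreadable from compound 2 to compound 4 is expected to be small. Compound 4 is therefore estimated at 1500 nM, between 400 nM and 6000 nM, with a fair chance that this assay again reports only a limit.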

Compound 4, half-maximal inhibitory concentration: 347 nM
The estimate for compound 4 lay 4.3-fold (0.64 log units) above the measured number, and the stated range ends above it.
By their numbers in this assay, from the lowest: compounds 1 and 3 (each within the scatter of the next); then compound 4. At a limit, above all of these: compound 2.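

Placing 1-benzofuran-2-yl in place of pyridin-3-yl on a double-bonded chain carbon bound to an aromatic carbon changes the result in this assay (an at least 2.8-fold lower number from compound 2 to compound 4 (0.45 log units; beyond the scatter)). For the compounds shown here, this position can therefore respond to the aromatic group it carries, which the one earlier exchange there did not show (a 1.9-fold higher number from compound 1 to compound 3 (0.28 log units; within the scatter)). Going by these compounds, compound 2 has only a limit, so the full size of its step stays unknown: the limit of > 1000 nM in this assay, at which 1 of the 4 values shown sits.

On these data alone, whether 1-benzofuran-2-yl would matter on the core of compound 1 remains open. So does the effect of a pyridine ring carrying an amine or a carboxylic acid at this place.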